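Lengthening the Chain of a Sulfinyl Isothiocyanate

This account rests on a few compounds, and the source may have more. Where it says the series, first, only, none or still open, it means among the compounds named here.

Measured compounds:
Compound 1, `CC(C)[S+]([O-])CCCCN=C=S`: 2050 nM
Compound 2, `CC(C)[S+]([O-])CCCCCN=C=S`: 3690 nM

Both compounds were tested in a functional assay on HepG2 cells (Homo sapiens) for cytotoxicity, read by MTT assay, with a stated time of 72 h; a higher number here means a weaker inhibitor, a lower number a stronger inhibitor. Compound 1 gives 2050 nM, and compound 2 gives 3690 nM. Among the compounds with values here, of the two numbers, that of compound 2 is the one standing higher, but the only step leading to it, a 1.8-fold higher number from compound 1 to compound 2 (0.26 log units; within the scatter), is within the scatter, so the two compounds cannot be told apart on these data.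

Compound 3, `CC(C)[S+]([O-])CCCCCCN=C=S`, has not yet been measured. It differs from compound 2 as follows: a group of 4 heavy atoms (2 carbon, 1 nitrogen, 1 sulfur; no ring) in place of a group of 3 heavy atoms (1 carbon, 1 nitrogen, 1 sulfur; no ring), on a saturated chain carbon, five bonds along the chain from a sulfur. Within the data shown here, the one measured step that bears on this change is a 1.8-fold higher number from compound 1 to compound 2 (0.26 log units; within the scatter), which is the same kind of chain lengthening one bond earlier along the chain, and it did not rise above the scatter. On that single precedent, a further lengthening in compound 3 is expected to shift the number in this assay little if at all, perhaps slightly upward, with the step of a 1.4-fold higher number from compound 2 to compound 3 (0.13 log units; within the scatter) as the estimate. Compound 3 is therefore expected to give about 5000 nM, within a range from 2500 nM to 10000 nM.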

Compound 3, half-maximal inhibitory concentration: 7820 nM
Estimate against measurement, compound 3: 1.6-fold (0.19 log units) below; the range from low to high includes it.
By their numbers in this assay, from the lowest: compounds 1 and 2 (each within the scatter of the next); then compound 3.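

In this assay the added chain carbon, five bonds along the chain from a sulfur, gives a 2.1-fold higher number from compound 2 to compound 3 (0.33 log units; beyond the scatter) and so moves the number modestly but measurably toward a weaker inhibitor. The earlier lengthening, a 1.8-fold higher number from compound 1 to compound 2 (0.26 log units; within the scatter), could not be told apart from the scatter, so this is the only step shown in which a change in the chain's length can be read as a real difference, and its size remains small. The compounds shown offer no measurement that accounts for this difference.

They leave open whether a longer chain would carry the number higher still or whether it would level off, and three chain lengths are too few to settle that. They also leave open how the number would respond to an amine or a carboxylic acid in place of the isothiocyanate, and whether the step seen here would hold in a compound with a different group on the sulfur.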